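A few compounds are considered here, and "the series" means these few. Any claim that something is new, unique, unknown or untested is made for them only; others in the source may bear on it.

Four compounds built on one shared core were examined in a functional assay on the whole organism (artery, strain albino) with Rattus norvegicus as the target, with a stated time of 600 min, at a dose of 10 mg/kg by the oral route; a lower number here means less inhibition, a higher number more inhibition at the dose given (going by the name of the read-out). Compound 1 `CC1=C(C(=O)Nc2ccc(Br)cc2)C(c2ccc(Cl)cc2Cl)N=C(SCc2cccc(Cl)c2)N1` gives 15.4% in this assay. Compound 2 `CC1=C(C(=O)Nc2ccc(Br)cc2)C(c2ccc(Cl)cc2Cl)N=C(SCc2ccc(Cl)cc2)N1` differs from compound 1 only by 4-chlorophenyl in place of 3-chlorophenyl on a saturated chain carbon bound to a sulfur, and in this assay compound 2 gives 30.3%, a step of a number 14.9 percentage points higher from compound 1 to compound 2 (beyond the scatter). Compound 3 `COc1ccc(C2N=C(SCc3cccc(Cl)c3)NC(C)=C2C(=O)Nc2ccc(Br)cc2)cc1` differs from compound 1 by 4-methoxyphenyl in place of 2,4-dichlorophenyl on a saturated ring carbon, and in this assay compound 3 gives 32.8%, a step of a number 17.4 percentage points higher from compound 1 to compound 3 (beyond the scatter). The numbers for compound 2 and compound 3 lie within the usual scatter of each other, so no order between them can be read.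

Compound 4 `COc1ccc(C2N=C(SCc3ccc(Cl)cc3)NC(C)=C2C(=O)Nc2ccc(Br)cc2)cc1` has not yet been measured. It differs from compound 3 by 4-chlorophenyl in place of 3-chlorophenyl on a saturated chain carbon bound to a sulfur, the same kind of change as that from compound 1 to compound 2, and at the same place, while the cores of the two pairs differ as described above for compound 3. Because that earlier change gave a number 14.9 percentage points higher from compound 1 to compound 2 (beyond the scatter), a step of similar size, a number 12.2 percentage points higher from compound 3 to compound 4 (beyond the scatter), is expected for compound 4, with some doubt that it carries over fully to the other core. On that basis compound 4 is estimated at 45% in this assay, most likely between 30% and 60%.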

Compound 4, a percentage reported as inhibition, in the whole organism at one dose (the size of the read-out at that dose, not a potency): 30.3%
The estimate for compound 4 lay 14.7 percentage points above the measured number; the measured number falls inside the stated range.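

In this assay, putting 4-chlorophenyl in place of 3-chlorophenyl on the saturated chain carbon bound to a sulfur gave a number 2.5 percentage points lower from compound 3 to compound 4 (within the scatter), and the rise seen with this change on the core of compound 1 did not appear on the core of compound 3: the same change on two cores in this assay, a number 14.9 percentage points higher (beyond the scatter) from compound 1 to compound 2 and a number 2.5 percentage points lower (within the scatter) from compound 3 to compound 4, 17.4 percentage points apart, beyond the scatter of two such steps. Seen from the other side, putting 4-methoxyphenyl in place of 2,4-dichlorophenyl on the saturated ring carbon gave no change at the digits printed from compound 2 to compound 4 (within the scatter), and this change also behaved differently in its two settings: the same change on two cores in this assay, a number 17.4 percentage points higher (beyond the scatter) from compound 1 to compound 3 and no change at the digits printed (within the scatter) from compound 2 to compound 4, 17.4 percentage points apart, beyond the scatter of two such steps. In these four compounds the two changes do not simply add up, and a step measured on one core cannot be assumed to hold on another, but the data do not show why this happens or how either change would behave on any further core.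

The compounds shown carry only chlorophenyl groups on the chain carbon bound to a sulfur. Going by these compounds, it remains open how a plain phenyl ring or a longer alkyl chain in that place would behave on either core.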